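A few compounds are considered here, and "the series" means these few. Any claim that something is new, unique, unknown or untested is made for them only; others in the source may bear on it.

In a functional assay on A549 cells (Homo sapiens) for cytotoxicity, read by WST assay, with a stated time of 24 h (a lower number here means a stronger inhibitor, a higher number a weaker inhibitor), compound 3 `COc1ccc2[nH]cc(/C=C(\C#N)C(=O)c3c[nH]c4cc(F)ccc34)c2c1` gives 18000 nM. Compound 1 `COc1ccc2c(/C=C(\C#N)C(=O)c3c[nH]c4cc(F)ccc34)c[nH]c2c1` gives 10300 nM, which lies within the usual scatter of compound 3. Among the measured compounds shown here, compound 2 `COc1ccc2[nH]cc(/C=C(\C#N)C(=O)c3c[nH]c4ccccc34)c2c1` gives 6600 nM, and this is the one compound clearly apart from compound 3. For the measured compounds named here, the only measured step that changes a single place is a 2.7-fold higher number from compound 2 to compound 3 (0.44 log units; beyond the scatter), a modest move beyond the scatter that comes with fluoro in place of hydrogen on an aromatic carbon.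

Compound 4 `COc1ccc2c(C(=O)/C(C#N)=C/c3c[nH]c4ccc(OC)cc34)c[nH]c2c1` has not yet been measured. It carries methoxy in place of fluoro on an aromatic carbon, and the full difference is methoxy in place of fluoro on an aromatic carbon. The fluoro that leaves is the same one the measured step brought in, so that step is the closest guide. Going by the values given here, no measured pair shows methoxy entering at this place, which leaves the evidence indirect. Compound 2, which has no fluoro, gives 6600 nM, so a partial move toward that number is a reasonable expectation, though methoxy is not hydrogen. The expected change is a 1.6-fold lower number from compound 3 to compound 4 (0.21 log units; within the scatter), an estimated drop to a lower number that stays within the scatter. The estimate for compound 4 is 11000 nM, with an expected range from 4500 nM to 26000 nM.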

Compound 4, half-maximal inhibitory concentration: 3700 nM
The estimate for compound 4 lay 3.0-fold (0.47 log units) above the measured number; the whole stated range lies above it.
By their numbers in this assay, from the lowest: compounds 4, 2, 1 and 3 (each within the scatter of the next, the first and the last beyond it).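

The fluoro group is what separates compound 3 from its neighbours here: in this assay, putting methoxy in its place gives a 4.9-fold lower number from compound 3 to compound 4 (0.69 log units; beyond the scatter), a step beyond the scatter that runs opposite in direction to the one seen when fluoro came in, a 2.7-fold higher number from compound 2 to compound 3 (0.44 log units; beyond the scatter). Methoxy brings two heavy atoms and a hydrogen-bond acceptor to this aromatic carbon, yet replacing hydrogen with it gives a 1.8-fold lower number from compound 2 to compound 4 (0.25 log units; within the scatter), which stays within the scatter, so the data do not separate hydrogen from methoxy at this place, and of the three groups compared here only fluoro stands apart, with the higher number. No measurement shown explains why fluoro differs from the other two groups at this place.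

The compounds shown leave open whether a chloro group, an amine or a longer chain such as ethoxy at this carbon would stay with hydrogen and methoxy or move with fluoro. They also leave open whether these three groups would fall in the same order elsewhere on the shared core.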